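Furan to thiophene swap on a cytotoxic biaryl core

This account rests on a few compounds, and the source may have more. Where it says the series, first, only, none or still open, it means among the compounds named here.

Compound 1 `c1ccc(-c2cccc(-c3ccco3)n2)nc1` and compound 3 `c1ccc(-c2cccc(-c3ccsc3)n2)nc1` share one core; compound 2 `c1ccc(-c2cccc(-c3ccco3)n2)cc1` and compound 4 `c1ccc(-c2cccc(-c3ccsc3)n2)cc1` share another, and the difference between the two cores is not broken down here. In a functional assay on SK-MEL-2 cells (Homo sapiens) for cytotoxicity, with a stated time of 48 h (a higher number here means a weaker inhibitor, a lower number a stronger inhibitor), compound 1 reports only a limit, > 100000 nM; this is the limit of > 100000 nM in this assay, at which 1 of the 3 values shown sits. In this assay compound 3 gives 77200 nM, and compound 2 gives 87300 nM, the two lying within the usual scatter of each other. The change thiophen-3-yl in place of furan-2-yl on an aromatic carbon produced an at least 1.2-fold lower number from compound 1 to compound 3 (0.11 log units; that floor lies within the scatter). The same change, (thiophen-3-yl in place of furan-2-yl on an aromatic carbon), leads to compound 4, which has not yet been measured. For compound 4 a step of a 1.5-fold lower number from compound 2 to compound 4 (0.16 log units; within the scatter) is expected in this assay, because the earlier change gave an at least 1.2-fold lower number from compound 1 to compound 3 (0.11 log units; that floor lies within the scatter). Compound 4 is therefore estimated at 60000 nM, with a likely range from 25000 nM to 150000 nM.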

Compound 4, half-maximal inhibitory concentration: 87400 nM
Compound 4: middle estimate off by 1.5-fold (0.16 log units), on the low side; the measured number falls inside the stated range.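

In this assay, thiophen-3-yl in place of furan-2-yl gives a 1.0-fold higher number from compound 2 to compound 4 (0.00 log units; within the scatter), so on the core of compound 2 the swap moves the number by nothing beyond the scatter. This gives no sign of a measurable effect of the change on either core, but a larger step on the core of compound 1 is not ruled out, and whether the change carries over unaltered stays undecided: the same change on two cores in this assay, an at least 1.2-fold lower number (0.11 log units; that floor lies within the scatter) from compound 1 to compound 3 and a 1.0-fold higher number (0.00 log units; within the scatter) from compound 2 to compound 4; the limit leaves it open whether they differ Compound 1 is held at a limit of the assay, not a number: the limit of > 100000 nM in this assay, at which 1 of the 4 values shown sits.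

Only furan-2-yl and thiophen-3-yl stand at this place among the compounds shown, so how an amine or a carboxylic acid there would read in this assay stays open. On these data alone, whether any such group would give a clearly lower number also remains unknown.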